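The source may report more compounds than this note shows. Statements on the series, on what has been measured and on what is new or still open speak of the compounds shown alone.

Measured compounds in an in vitro functional assay on HEK285-7 cells for antagonist activity at prostaglandin D2 receptor 2 (Homo sapiens), read by BRET and beta-arrestin recruitment; a higher number here means a weaker inhibitor, a lower number a stronger inhibitor:
Compound 1 `O=C(O)Cc1sc(C(c2ccccc2)c2ccc(F)cc2)nc1-c1ccc(Cl)cc1` gives 36 nM.
Compound 2 `O=C(O)Cc1sc(C(c2ccc(F)cc2)c2ccc(F)cc2)nc1-c1ccc(Cl)cc1` gives 180 nM.
Compound 3 `O=C(O)Cc1sc(C(c2ccccc2)c2ccccc2)nc1-c1cccc(F)c1` gives 29 nM.

Compound 1 and compound 2 share a core and differ only by fluoro in place of hydrogen on an aromatic carbon, a change that produced a 5.0-fold higher number from compound 1 to compound 2 (0.70 log units; beyond the scatter). Compound 4 `O=C(O)Cc1sc(C(c2ccccc2)c2ccccc2)nc1-c1ccc(F)c(F)c1` stands to compound 3 in a similar way: the difference is fluoro in place of hydrogen on an aromatic carbon. How the core of compound 3 differs from the core of compound 1 is not broken down here. The two changes are the same kind of change, not the same: in compound 4 the entering fluoro is ortho to a fluoro group as well as para to a large group, whereas in compound 2 it is only para to a large group. Because the same kind of change gave a 5.0-fold higher number from compound 1 to compound 2 (0.70 log units; beyond the scatter), compound 4 is expected to be somewhat weaker in this assay, with an expected step of a 2.2-fold higher number from compound 3 to compound 4 (0.35 log units; beyond the scatter). The estimate for compound 4 is 65 nM, between 25 nM and 170 nM.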

Compound 4, half-maximal inhibitory concentration: 43 nM
Estimate against measurement, compound 4: 1.5-fold (0.18 log units) above; the range from low to high includes it.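

In this assay, fluoro in place of hydrogen on an aromatic carbon gave a 1.5-fold higher number from compound 3 to compound 4 (0.17 log units; within the scatter). The change therefore did not carry over at the same size from one core to the other: the same change on two cores in this assay, a 5.0-fold higher number (0.70 log units; beyond the scatter) from compound 1 to compound 2 and a 1.5-fold higher number (0.17 log units; within the scatter) from compound 3 to compound 4, 3.4-fold (0.53 log units) apart, beyond the scatter of two such steps. Going by these compounds alone, each core offers only one pair, and the entering fluoro is ortho to a fluoro group in compound 4 but not in compound 2, so these data cannot separate the effect of the core from that of this local difference.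

From the compounds shown here alone, it remains open whether a methoxy or a nitrile in place of the same hydrogen would follow either step. Also open, going by these compounds, is how the change would behave on further cores.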